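Swapping the chain on compound 3 for a fluorinated ring

This account rests on a few compounds, and the source may have more. Where it says the series, first, only, none or still open, it means among the compounds named here.

Three compounds share a core and differ in the groups hung on it. Compound 1 `CC(C)CCn1nc(C2CCC2)c(O)c(C2=NS(=O)(=O)c3cc(NS(C)(=O)=O)ccc3N2)c1=O` gives 0.317 h in an in vitro ADME assay on microsomes from liver (Homo sapiens) for metabolic stability, tested at 5 uM; a higher number here means that the compound lasts longer, a lower number that the compound disappears faster. Compound 2 `CC(C)CCn1nc(CC2CCC2)c(O)c(C2=NS(=O)(=O)c3cc(NS(C)(=O)=O)ccc3N2)c1=O` gives 0.417 h in this assay, and the step of a 1.3-fold higher number from compound 1 to compound 2 (0.12 log units; within the scatter) is small. Compound 3 `CCC(C)(C)Cn1nc(-c2cccs2)c(O)c(C2=NS(=O)(=O)c3cc(NS(C)(=O)=O)ccc3N2)c1=O` gives > 1 h in this assay, which is a limit of the assay rather than a number. So compound 3 cannot be placed against the other two with a number; it is known only because of the limit of > 1 h in this assay, at which 1 of the 3 values shown sits.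

Compound 4 `CS(=O)(=O)Nc1ccc2c(c1)S(=O)(=O)N=C(c1c(O)c(-c3cccs3)nn(CC3(C(F)(F)F)CC3)c1=O)N2` differs from compound 3 by 1-(trifluoromethyl)cyclopropyl in place of 1,1-dimethylpropyl on a saturated chain carbon bound to an aromatic nitrogen. Among the compounds with values here, no measured step touches this part of the molecule; the only measured step sits on the aromatic carbon, stays within the scatter and says nothing about the chain on the nitrogen. The expectation for the step that the limit leaves unreadable from compound 3 to compound 4 is therefore little change beyond the scatter, with compound 4 likely to remain at the limit. Compound 4 is estimated at 1.5 h in this assay, between 0.7 h and 3 h.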

Compound 4, half-life: > 1 h
Compound 4: only a limit was reported; the forecaster's own chance of this, stated with the estimate: 60%; the middle value is on the limit's open side.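

Compound 3 and compound 4 each stop at a limit of the assay rather than a number, so the step between them cannot be read: the limit of > 1 h in this assay, at which 2 of the 4 values shown sit. The compounds shown leave open how long either one actually lasts in this assay, and whether swapping the chain changes that.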